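Rearranged amine ring on compound 1: half-life notes

This account rests on a few compounds, and the source may have more. Where it says the series, first, only, none or still open, it means among the compounds named here.

In an ADME assay on microsomes from liver (Rattus norvegicus) for metabolic stability, read by LC-MS, using NADPH, at 37 degrees C (on this read-out lower numbers stand for a shorter-lived compound and higher numbers for a longer-lived compound), compound 1 (`Cc1ccccc1-c1nc(CN2CCC(C(=O)NCCCN3CC(C)(C)CC(C)(C)C3)CC2)c(C)o1`) gives 0.095 h and compound 3 (`Cc1oc(-c2c(Cl)cccc2Cl)nc1CN1CCC(C(=O)NCCCN2C[C@H](C)C[C@H](C)C2)CC1`) gives 0.0483 h and these two values lie within the scatter of each other. Compound 2 (`Cc1oc(-c2ccc(Cl)cc2)nc1CN1CCC(C(=O)NCCCN2C[C@H](C)C[C@H](C)C2)CC1`) gives > 0.5 h as a limit of the assay, not a number.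

The change to compound 4 (`Cc1ccccc1-c1nc(CN2CCC(C(=O)NCCCN3CCCC(CC(C)C)C3)CC2)c(C)o1`) is a group of 10 heavy atoms (9 carbon, 1 nitrogen; one six-membered non-aromatic ring with 1 hetero atom) in place of a group of 10 heavy atoms (9 carbon, 1 nitrogen; one six-membered non-aromatic ring with 1 hetero atom), on a saturated chain carbon, three bonds along the chain from an amide-type nitrogen and the two structures have the same atoms, joined differently. Within the data shown here, the only measured step is an at least 10-fold lower number from compound 2 to compound 3 (1.01 log units; beyond the scatter) and it lies beyond the scatter, but it puts 2,6-dichlorophenyl in place of 4-chlorophenyl on an aromatic carbon, not at the place changed here. Among the measured compounds shown here, with no measured step at that place, the value of compound 1 at 0.095 h remains the anchor, and no step beyond the scatter is expected in this assay for this change. The expected step is a 1.4-fold lower number from compound 1 to compound 4 (0.13 log units; within the scatter) and this estimate stays within the scatter. Compound 4 is estimated at 0.07 h with an expected range from 0.03 h to 0.2 h in this series.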

Compound 4, half-life: 0.0383 h
Beside the measured number, compound 4's estimate is 1.8-fold (0.26 log units) above it; the measured number falls inside the stated range.
By their numbers in this assay, from the lowest: compounds 4, 3 and 1 (each within the scatter of the next, the first and the last beyond it). At a limit, above all of these: compound 2.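

In this assay, the amine ring at this place is not indifferent to rearrangement: with the same atoms joined differently, on a saturated chain carbon, three bonds along the chain from an amide-type nitrogen, the half-life shows a 2.5-fold lower number from compound 1 to compound 4 (0.39 log units; beyond the scatter). Among these compounds, the earlier step beyond the scatter concerned only 2,6-dichlorophenyl in place of 4-chlorophenyl on an aromatic carbon, so this modest step is the first sign, from a single pair, that the amine end also shifts the read-out. Nothing measured here accounts for the step.

On these data alone, whether a morpholine or an unsubstituted piperidine at this place would lengthen or shorten the half-life remains open. Also open, as far as these compounds go, is whether the same rearrangement gives a step of similar size with 4-chlorophenyl on the shared core.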